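The compounds below may be only part of what the source reports. "The series", "measured", "known", "first", "only" and "open" are said of these compounds alone.

Compound 2, `O=C(Nc1ccc(Oc2ccnc3[nH]ccc23)c(F)c1)c1cc2cccnc2n(-c2ccccc2)c1=O`, is the reference point of this account. In a functional assay on NCI-H460 cells (Homo sapiens) for antiproliferative activity, read by MTT assay, with a stated time of 72 h (a lower number here means a stronger inhibitor, a higher number a weaker inhibitor), compound 2 gives 180 nM. For the measured compounds named here, the only other compound with a number is compound 1, `O=C(Nc1ccc(Oc2ccnc3[nH]ccc23)cc1)c1cc2cccnc2n(-c2ccc(F)cc2)c1=O`, and in this assay compound 1 gives 190 nM. Compound 2 thus holds the lowest of the two numbers, but the gap to compound 1 lies within the scatter, so the two cannot be told apart on this showing.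

Compound 3, `O=C(Nc1ccc(Oc2ccnc3[nH]ccc23)c(F)c1)c1cc2cccnc2n(-c2ccc(F)cc2)c1=O`, has not been measured. Relative to compound 2 the change is fluoro in place of hydrogen on an aromatic carbon; read one bond further out, it is phenyl to 4-fluorophenyl. Compound 3 therefore carries both the fluorophenyl of compound 1 and the fluorinated aniline ring of compound 2. Going by the values given here, no step between two measured compounds is known for this change, so no size can be read from the data. Since compound 1 and compound 2 sit so close, the step of a 1.1-fold lower number from compound 2 to compound 3 (0.02 log units; within the scatter) is expected to be small, with no direction beyond the scatter. Compound 3 is estimated at 170 nM, within 80 nM to 360 nM.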

Compound 3, half-maximal inhibitory concentration: 87 nM
Estimate against measurement, compound 3: 2.0-fold (0.29 log units) above; measured number inside the range.
By their numbers in this assay, from the lowest: compound 3; then compounds 2 and 1 (each within the scatter of the next).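

In (this assay), the change from phenyl to 4-fluorophenyl now has a size that can be read, and the step is modest but beyond the scatter (a 2.1-fold lower number from compound 2 to compound 3 (0.32 log units; beyond the scatter)). The fluoro on the aniline ring, which compound 3 carries and compound 1 lacks, also has a step of its own, again beyond the scatter (a 2.2-fold lower number from compound 1 to compound 3 (0.34 log units; beyond the scatter)). Neither of the earlier compounds could show this, since they differ in two places, whereas compound 3 is one change away from each, and both changes lower the number; nothing measured here bears on the reason for either step.

Going by these compounds, only fluoro is seen at the place para to a large group, so it remains open whether chloro, methoxy or an amine there would lower the number in the same way. On these data alone, each step also rests on a single pair of compounds, so it is unknown whether the two fluoro groups would act alike on another core, or whether a second fluoro on either ring would take the number lower still.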